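Compound 1 without its (1-bromoethenyl)carbonyl group

The source may hold more compounds than are shown below. What is called first, only, known or untested is meant among the compounds shown, and "the series" means these compounds.

Measured in a functional assay on HeLa cells (Homo sapiens) for antiproliferative activity, with a stated time of 48 h; on this read-out higher numbers stand for weaker inhibition and lower numbers for stronger inhibition:
- compound 1 (`C=C(Br)C(=O)Nc1ccc(/C=C/C(=O)c2cc(OC)c(OC)c(OC)c2)cc1`): (1100 nM)
- compound 2 (`C=C(Br)C(=O)Nc1ccc(C(=O)/C=C/c2ccc(OC)c(OC)c2)cc1`): (770 nM)
- compound 3 (`C=C(Br)C(=O)Nc1ccc(C(=O)/C=C/c2cc(OC)c(OC)c(OC)c2)cc1`): (420 nM)

Compound 1 stands level with compound 2 within the usual scatter, and its number is clearly higher than that of compound 3. The next compound to test, compound 4 (`COc1cc(C(=O)/C=C/c2ccc(N)cc2)cc(OC)c1OC`), differs from compound 1 in one place (hydrogen in place of (1-bromoethenyl)carbonyl on a nitrogen on an aromatic ring): hydrogen in place of (1-bromoethenyl)carbonyl on a nitrogen on an aromatic ring.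

Within the data shown here, only one measured step links two compounds that differ in a single place (a 1.8-fold lower number from compound 2 to compound 3 (0.26 log units; within the scatter)). It is small, within the scatter, and concerns methoxy in place of hydrogen on an aromatic carbon, so it says nothing about this change. Among the measured compounds shown here, all three measured compounds carry the (1-bromoethenyl)carbonyl group, so the data show no compound without it. What follows is therefore a judgement with a wide range, leaning towards a higher number, meaning weaker inhibition. The expected step is sizeable (a 4.5-fold higher number from compound 1 to compound 4 (0.66 log units; beyond the scatter)). For compound 4 the estimated value is (5000 nM), with an expected range from (1000 nM) to (25000 nM).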

Compound 4, half-maximal inhibitory concentration: 1900 nM
Compound 4: the middle estimate sits 2.6-fold (0.42 log units) above what was measured, within the range that was stated.
By their numbers in this assay, from the lowest: compounds 3, 2, 1 and 4 (each within the scatter of the next, the first and the last beyond it).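

In this assay, replacing the (1-bromoethenyl)carbonyl group on the nitrogen with hydrogen, which turns ((1-bromoethenyl)carbonyl)amino into amino, gives a 1.7-fold higher number from compound 1 to compound 4 (0.24 log units; within the scatter) and so stays within the usual scatter. On the core of compound 1, then, this group is not needed for antiproliferative activity at this level, and the five heavy atoms it adds make no difference that this read-out can separate from scatter. Nothing measured here on how either compound acts explains this outcome.

On these data alone, whether the same swap would leave compound 2 and compound 3 equally unchanged remains open, since their cores differ from that of compound 1. As far as these compounds go, it is also open how an acetyl group or a (1-chloroethenyl)carbonyl group on the same nitrogen would compare.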